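The compounds below may be only part of what the source reports. "The series", "measured", "known", "first", "only" and "open" are said of these compounds alone.

In a physicochemical assay for solubility (a lower number here means a less soluble compound, a higher number a more soluble compound), compound 2, with the structure `CNC(=O)c1cc(C(=O)NC)c2c(c1)[C@H](c1ccccc1)CO2`, gives >= 130 ug/mL, which is a limit of the assay rather than a number. Compound 1, `CNC(=O)c1cc(C(=O)N[C@H]2[C@@H]3C[C@@H](O)C[C@@H]32)cc2c1OC[C@H]2c1ccccc1`, shares the core of compound 2 and differs from it by a group of 7 heavy atoms (6 carbon, 1 oxygen; one three-membered non-aromatic ring of carbon only, one five-membered non-aromatic ring of carbon only) in place of one carbon atom, on an amide-type nitrogen. In this assay compound 1 gives >= 124 ug/mL, again a limit and not a number. The step that the two limits leave unreadable from compound 2 to compound 1 cannot be read in size, because the limit of >= 130 ug/mL in this assay, at which 1 of the 3 values shown sits, and the limit of >= 124 ug/mL in this assay, at which 1 of the 3 values shown sits, both sit at a limit.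

Compound 3, `CNC(=O)c1cc(C(=O)NC)c2c(c1)[C@](C)(c1ccccc1)CO2`, is built on a core that differs from the core of compound 2; the difference between the two cores is not broken down here. In this assay compound 3 gives >= 132 ug/mL, which is once more a limit, as the limit of >= 132 ug/mL in this assay, at which 1 of the 3 values shown sits, shows.

Compound 4, `CNC(=O)c1cc(C(=O)N[C@H]2[C@@H]3C[C@@H](O)C[C@@H]32)cc2c1OC[C@@]2(C)c1ccccc1`, carries the same change on the core of compound 3 that was made from compound 2 to compound 1, namely (a group of 7 heavy atoms (6 carbon, 1 oxygen; one three-membered non-aromatic ring of carbon only, one five-membered non-aromatic ring of carbon only) in place of one carbon atom, on an amide-type nitrogen), at a place described in the same words. The earlier occurrence of this change left both ends at a limit, so the expected step of an at least 1.0-fold lower number from compound 3 to compound 4 (0.00 log units; that floor lies within the scatter) from compound 3 to compound 4 is estimated to be small and most likely to land at the limit again. Compound 4 is therefore expected to give about 130 ug/mL in this assay, with an estimated range from 60 ug/mL to 220 ug/mL, resting on the unreadable step that the two limits leave unreadable from compound 2 to compound 1 and on the limits the limit of >= 124 ug/mL in this assay, at which 1 of the 3 values shown sits, and (the limit of >= 132 ug/mL in this assay, at which 1 of the 3 values shown sits).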

Compound 4, solubility: >= 209 ug/mL
Compound 4: no number, only a limit; the forecaster's own chance of this, stated with the estimate: 75%; middle value at least 1.6-fold (0.20 log units) away from the limit.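

In this assay compound 4 gives >= 209 ug/mL, which is a limit of the assay and not a number. Compound 3 also stands at a limit, so no size can be read for the step between compound 3 and compound 4. The compounds shown leave open where the actual solubility of each lies, and whether replacing the methyl on the amide-type nitrogen with this group changes it at all.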